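Methoxyphenyl shift from compound 2 to compound 3

This account rests on a few compounds, and the source may have more. Where it says the series, first, only, none or still open, it means among the compounds named here.

Among the measured compounds shown here, in a functional assay on HT-1080 cells (Homo sapiens) for cytotoxicity, read by MTT assay, with a stated time of 72 h (a higher number here means a weaker inhibitor, a lower number a stronger inhibitor), compound 1 (`COc1cccc(/C=C2\CCC/C(=C\c3ccc(Br)cc3)C2=O)c1OC`) gives 13700 nM and compound 2 (`COc1ccccc1/C=C1\CCC/C(=C\c2cccc(OC)c2OC)C1=O`) gives 14100 nM so compound 2 stands level with the only other measured number, within the scatter.

Compound 3 (`COc1cccc(/C=C2\CCC/C(=C\c3cccc(OC)c3OC)C2=O)c1`) has the same atoms as compound 2, joined differently: 3-methoxyphenyl in place of 2-methoxyphenyl on a double-bonded chain carbon bound to a double-bonded ring carbon.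

For the measured compounds named here, one measured step bears on this place: 2-methoxyphenyl in place of 4-bromophenyl gave a 1.0-fold higher number from compound 1 to compound 2 (0.01 log units; within the scatter) which lies within the scatter. Going by the values given here, no measured compound carries 3-methoxyphenyl there, so this evidence is indirect. No step beyond the scatter is therefore expected in this assay for this change.

The estimated step is a 1.0-fold lower number from compound 2 to compound 3 (0.00 log units; within the scatter) on this reading. Compound 3 is expected at 14000 nM with an estimated range of 6000 nM to 30000 nM as the working figures.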

Compound 3, half-maximal inhibitory concentration: 9900 nM
Compound 3: middle estimate off by 1.4-fold (0.15 log units), on the high side; the range from low to high includes it.
By their numbers in this assay, from the lowest: compounds 3, 1 and 2 (each within the scatter of the next).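

In this assay, 3-methoxyphenyl in place of 2-methoxyphenyl on a double-bonded chain carbon bound to a double-bonded ring carbon gives a 1.4-fold lower number from compound 2 to compound 3 (0.15 log units; within the scatter) and so adds a second methoxyphenyl placement without a step beyond the scatter. Against the bromo-bearing group, 3-methoxyphenyl gives a 1.4-fold lower number from compound 1 to compound 3 (0.14 log units; within the scatter) in the same assay, so 4-bromophenyl, 2-methoxyphenyl and 3-methoxyphenyl all stand level at this place. No supporting measurement bears on this result, so the level values remain without explanation.

Still open, on these data alone, is whether a different kind of group at this place, such as an amine or a carboxylic acid, would give a step beyond the scatter. The rest of the shared core is the same in all three compounds, so its contribution to the values cannot be read from them.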